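The source may hold more compounds than are shown below. What is called first, only, known or untested is meant among the compounds shown, and "the series" means these compounds.

Measured so far in an ADME assay on MDBK cells (Bos taurus) for cytotoxicity; on this read-out lower numbers stand for higher toxicity in this test and higher numbers for lower toxicity in this test:
- Compound 1 `Fc1cccc(F)c1Cn1c(-c2c(F)cccc2F)nc2ccncc21`: 99000 nM
- Compound 2 `Cc1ccccc1Cn1ccc2nc(-c3ccccc3)nc-2c1`: > 100000 nM

In this assay, compound 2 has no exact number, only the limit > 100000 nM. For the measured compounds named here, this is the one reading of that kind so far: the limit of > 100000 nM in this assay, at which 1 of the 2 values shown sits.

Compound 3 `Fc1ccccc1Cn1ccc2nc(-c3ccccc3)nc-2c1` differs from compound 2 in one place, a 2-methylphenyl becoming a 2-fluorophenyl: fluoro in place of methyl on an aromatic carbon. The exchanged group sits ortho to a large group.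

Going by the values given here, no measured step between compounds gives the size of this change. No shift beyond the usual scatter is expected in this assay, in either direction. Compound 1, which also carries fluoro on aromatic carbons, gives 99000 nM.

For compound 3, the expected value is 100000 nM, with an estimated range of 60000 nM to 160000 nM. This estimate means an expected step of a number no higher from compound 2 to compound 3 (the limit leaves the size open).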

Compound 3, half-maximal cytotoxic concentration: > 100000 nM
Compound 3: a limit, no number; the forecaster's own chance of this, stated with the estimate: 75%; the middle value sits exactly at the limit.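

In this assay compound 3 gives > 100000 nM, a limit and not a number. Compound 2 also stands at a limit, and no step can be read between compound 2 and compound 3. The compounds shown leave open whether fluoro in place of methyl on an aromatic carbon changes this read-out at all.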